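Compound 3 and a bromophenyl acid

The source may hold more compounds than are shown below. What is called first, only, known or untested is meant among the compounds shown, and "the series" means these compounds.

Compound 1 `COC(=O)CNc1cc(CS(=O)(=O)/C=C/c2c(OC)cc(OC)cc2OC)ccc1OC`: 100 nM
Compound 2 `COC(=O)C(Nc1cc(CS(=O)(=O)/C=C/c2c(OC)cc(OC)cc2OC)ccc1OC)c1ccccc1`: 75 nM
Compound 3 `COc1cc(OC)c(/C=C/S(=O)(=O)Cc2ccc(OC)c(NCCC(=O)O)c2)c(OC)c1`: 5000 nM

In a functional assay on DU-145 cells (Homo sapiens) for cytotoxicity, read by trypan blue exclusion, with a stated time of 96 h (a higher number here means a weaker inhibitor, a lower number a stronger inhibitor), compound 3 gives 5000 nM, the highest number of the three and so the weakest inhibitor here. Compound 4 `COc1cc(OC)c(/C=C/S(=O)(=O)Cc2ccc(OC)c(NC(C(=O)O)c3ccc(Br)cc3)c2)c(OC)c1` carries (4-bromophenyl)(carboxy)methyl in place of 2-carboxyethyl on a nitrogen on an aromatic ring. Adding phenyl to the ester changed little: a 1.3-fold lower number from compound 1 to compound 2 (0.12 log units; within the scatter). Two steps away from the esters were large: a 50-fold higher number from compound 1 to compound 3 (1.70 log units; beyond the scatter) and a 67-fold higher number from compound 2 to compound 3 (1.82 log units; beyond the scatter). Compound 4 keeps a carboxy group but loses the 2-carboxyethyl, and these data cannot separate those two features, so only a partial recovery seems reasonable. The expected move in this assay is large and downward: a 17-fold lower number from compound 3 to compound 4 (1.22 log units; beyond the scatter). Compound 4 is estimated at 300 nM, with an expected range from 50 nM to 3000 nM.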

Compound 4, half-maximal inhibitory concentration: 300 nM
Estimate against measurement, compound 4: no gap at the digits printed, and the stated range covers the measured number.
By their numbers in this assay, from the lowest: compounds 2 and 1 (each within the scatter of the next); then compound 4; then compound 3.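

In this assay, a carboxylic acid on this nitrogen is not always as poor as compound 3 suggested: replacing 2-carboxyethyl with (4-bromophenyl)(carboxy)methyl gives a 17-fold lower number from compound 3 to compound 4 (1.22 log units; beyond the scatter). A modest gap to the esters remains, with a 3.0-fold higher number from compound 1 to compound 4 (0.48 log units; beyond the scatter) and a 4.0-fold higher number from compound 2 to compound 4 (0.60 log units; beyond the scatter). No measurement shown explains this change.

The compounds shown cannot tell whether the bromine, the aromatic ring or the altered chain carries the step. A plain phenyl acid lacking bromine, or a primary amide in place of the acid, would help separate them.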